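The compounds below may be only part of what the source reports. "The series", "measured", "known", "first", "only" and "open" are said of these compounds alone.

Compound 2 `CC(C)(C)c1ccc(C(=O)N2CCC3(CC2)C(=O)N(CC(=O)NCCCCCNS(C)(=O)=O)CN3c2ccccc2)cc1` gives 5500 nM in an assay on HEK293 cells for displacement of a labelled ligand from NPC1-like intracellular cholesterol transporter 1 (Homo sapiens) (on this read-out lower numbers stand for stronger inhibition and higher numbers for weaker inhibition), and so stands with the higher of the two numbers measured. The other measured member of the series is compound 1 `CC(C)(C)c1ccc(C(=O)N2CCC3(CC2)C(=O)N(CC(=O)NCCO)CN3c2ccccc2)cc1`, which in this assay gives 1000 nM. Going by the values given here, the only step known so far runs between these two: a 5.5-fold higher number from compound 1 to compound 2 (0.74 log units; beyond the scatter), where the short hydroxy-bearing chain of compound 1 is exchanged for a longer chain ending in a methanesulfonamide.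

Compound 3 `CC(C)(C)c1ccc(C(=O)N2CCC3(CC2)C(=O)N(CC(=O)N2CCCC(CO)C2)CN3c2ccccc2)cc1` has not been measured. It differs from compound 2 as follows: 3-(hydroxymethyl)piperidin-1-yl in place of (5-(methanesulfonamido)pentyl)amino on a carbonyl carbon. The change removes the sulfonamide-bearing chain altogether and brings back a single hydroxyl, now carried on a saturated ring closed onto the amide nitrogen. The step from compound 1 to compound 2 bears on this directly, since the loss of the hydroxy-bearing chain in favour of the sulfonamide chain coincided with a clearly higher number. Returning to a hydroxy-bearing substituent is therefore expected to give a lower number in this assay, of a size about a 3.7-fold lower number from compound 2 to compound 3 (0.56 log units; beyond the scatter), though the ring is a new feature with no precedent here. The estimate for compound 3 is 1500 nM, with a range from 500 nM to 5000 nM.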

Compound 3, half-maximal inhibitory concentration: 8200 nM
For compound 3 the middle estimate is 5.5-fold (0.74 log units) below the measured one; measured number outside the range, above it.
By their numbers in this assay, from the lowest: compound 1; then compounds 2 and 3 (each within the scatter of the next).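

The exchange at this carbonyl carbon gives a 1.5-fold higher number from compound 2 to compound 3 (0.17 log units; within the scatter) in this assay, so 3-(hydroxymethyl)piperidin-1-yl and (5-(methanesulfonamido)pentyl)amino cannot be told apart here, although only the first carries a hydroxyl. The comparison with the other hydroxyl-bearing substituent, (2-hydroxyethyl)amino, gives an 8.2-fold higher number from compound 1 to compound 3 (0.91 log units; beyond the scatter), which shows that a hydroxyl in the group at this place does not by itself go with the lowest number of the series, and that the sulfonamide end of the chain is not needed for a number clearly higher than that of compound 1. Nothing available here gives a reason for either step.

Going by these compounds, what remains open is whether the difference from compound 1 goes with the piperidine ring itself or with the placing of the hydroxymethyl on it, a question that plain piperidin-1-yl and 4-(hydroxymethyl)piperidin-1-yl would address. Also open, on these data alone, is how chain length and end group each count, which (5-hydroxypentyl)amino, with a hydroxyl at the end of a pentyl chain, would help to separate.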